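This account rests on a few compounds, and the source may have more. Where it says the series, first, only, none or still open, it means among the compounds named here.

Measured so far:
compound 1, `N[C@H]1CC[C@H](Nc2c(C(=O)NCc3ccc(F)cc3)nc(Br)c3cccnc23)CC1`, 5000 nM in a functional assay on LNCaP cells (Homo sapiens) for cytotoxicity, read by MTT assay, with a stated time of 72 h; a higher number here means a weaker inhibitor, a lower number a stronger inhibitor
compound 2, `O=C(NCc1ccc(F)cc1)c1nc(Br)c2cccnc2c1N1CCNCC1`, 4500 nM in this assay

Compound 2 sits at the lower end of these two numbers, but a 1.1-fold lower number from compound 1 to compound 2 (0.05 log units; within the scatter) lies within the scatter, so the two cannot be told apart. Compound 3, `Nc1cccc(Nc2c(C(=O)NCc3ccc(F)cc3)nc(Br)c3cccnc23)c1`, differs from compound 2 by (3-aminophenyl)amino in place of piperazin-1-yl on an aromatic carbon. For the measured compounds named here, no measured step exchanges piperazin-1-yl for (3-aminophenyl)amino; the only step available, a 1.1-fold lower number from compound 1 to compound 2 (0.05 log units; within the scatter), changed the same place without moving the number beyond the scatter. Compound 3 is therefore expected to give 5000 nM in this assay, between 2000 nM and 12000 nM. The expected step is a 1.1-fold higher number from compound 2 to compound 3 (0.05 log units; within the scatter), within the scatter.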

Compound 3, half-maximal inhibitory concentration: 8000 nM
Compound 3: the middle estimate sits 1.6-fold (0.20 log units) below what was measured; measured number inside the range.
By their numbers in this assay, from the lowest: compounds 2, 1 and 3 (each within the scatter of the next).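

In this assay, a carbon-only aromatic ring on this aromatic carbon, para to the bromo group, gives a 1.8-fold higher number from compound 2 to compound 3 (0.25 log units; within the scatter) and also a 1.6-fold higher number from compound 1 to compound 3 (0.20 log units; within the scatter) as the exchange on the nitrogen. The piperazin-1-yl, (4-aminocyclohexyl)amino and (3-aminophenyl)amino groups therefore cannot be told apart here, so an aromatic ring serves at this place as well as the two non-aromatic rings. No available evidence explains this.

Still open, from the compounds shown here alone, is whether a carboxylic acid or a longer alkyl chain at this place would move the number beyond the scatter.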